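Adding a sulfamoyl group to compound 1

This account rests on a few compounds, and the source may have more. Where it says the series, first, only, none or still open, it means among the compounds named here.

Compound 1 `CC(C)n1ncc2c(C(=O)Nc3ccc(F)cc3)cc(-c3cccs3)nc21` gives > 200000 nM in an ADME assay on LLC-MK2 cells (Macaca mulatta) for cytotoxicity, read by spectrophotometry and crystal violet staining, with a stated time of 4 days (on this read-out higher numbers stand for lower toxicity in this test and lower numbers for higher toxicity in this test), and this is a limit of the assay, not a number. Compound 3 `CC(C)n1ncc2c(C(=O)Nc3ccc(F)cc3)cc(-c3ccsc3)nc21` gives > 200000 nM in this assay, which is also a limit. Compound 1 therefore stands at the limit of > 200000 nM in this assay, at which 2 of the 3 values shown sit. Among the compounds with values here, compound 2 `CC(C)n1ncc2c(C(=O)Nc3ncccn3)cc(-c3cccs3)nc21` gives 75000 nM, the only true number so far.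

Compound 4 `CC(C)n1ncc2c(C(=O)Nc3ccc(F)c(S(N)(=O)=O)c3)cc(-c3cccs3)nc21` differs from compound 1 as follows: sulfamoyl in place of hydrogen on an aromatic carbon. The sulfamoyl group takes the place of hydrogen on an aromatic carbon, ortho to a fluoro group and meta to a large group.

Within the data shown here, no measured step adds this group, so the evidence is indirect. The closest is an at least 2.6-fold lower number from compound 1 to compound 2 (0.42 log units; beyond the scatter), where pyrimidin-2-yl replaces the same 4-fluorophenyl group that compound 4 alters. The other, a step that the two limits leave unreadable from compound 1 to compound 3, swaps thiophen-2-yl for thiophen-3-yl elsewhere in the molecule and gives no readable size. A modest move towards a lower number is therefore expected, though a result at the limit would be no surprise. The expected change is an at least 1.4-fold lower number from compound 1 to compound 4 (0.15 log units; that floor lies within the scatter). For compound 4 the estimate is 140000 nM, with an expected range of 50000 nM to 200000 nM.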

Compound 4, half-maximal cytotoxic concentration: 50000 nM
Compound 4: the middle estimate sits 2.8-fold (0.45 log units) above what was measured; the measured number falls inside the stated range.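

In this assay, sulfamoyl in place of hydrogen on an aromatic carbon, ortho to a fluoro group and meta to a large group, gives an at least 4.0-fold lower number from compound 1 to compound 4 (0.60 log units; beyond the scatter). Within the data shown here, until now the only true number had come from replacing the whole 4-fluorophenyl group, in compound 2, whereas compound 4 keeps that ring and shows that one added group on one of its aromatic carbons is enough to bring the read-out down from the limit towards higher toxicity in this test. Compound 1 stands at a limit of the assay and not at a number, so the size of this step is only a floor: the limit of > 200000 nM in this assay, at which 2 of the 4 values shown sit.

The compounds shown leave open whether the step belongs to the sulfamoyl group itself or would also come with another group on this carbon, such as an amine or a carboxylic acid. They also leave open whether sulfamoyl would act in the same way on compound 3, which carries thiophen-3-yl in place of thiophen-2-yl, since the step from compound 1 to that compound cannot be read.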